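Swapping the benzyl-ether aryl group toward an ethoxy variant

A few compounds are considered here, and "the series" means these few. Any claim that something is new, unique, unknown or untested is made for them only; others in the source may bear on it.

Of the compounds shown here, three sharing one core have been measured so far in a functional assay on PC-3 cells (Homo sapiens) for cytotoxicity, read by sulforhodamine B assay; a lower number here means a stronger inhibitor of growth, a higher number a weaker inhibitor of growth. Compound 1 `COc1cccc(OC)c1OCCNCCOc1ccccc1OCc1ccccc1Cl` gives 17800 nM, compound 2 `COc1cccc(OC)c1OCCNCCOc1ccccc1OCc1ccc([N+](=O)[O-])cc1` gives 43600 nM, and compound 3 `COc1ccccc1COc1ccccc1OCCNCCOc1c(OC)cccc1OC` gives 30200 nM. Compound 3 thus holds the second highest of the three numbers, and both of its neighbours sit close: its gap to compound 2 and its gap to compound 1 each lie within the usual scatter, so no ordering among them can be read with confidence.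

The next compound, compound 4 `CCOc1ccc(COc2ccccc2OCCNCCOc2c(OC)cccc2OC)cc1`, differs from compound 3 in one place: 4-ethoxyphenyl in place of 2-methoxyphenyl on a saturated chain carbon bound to an oxygen on an aromatic ring.

Two earlier steps touch the same position on the chain carbon. The change a 2.4-fold higher number from compound 1 to compound 2 (0.39 log units; beyond the scatter) is the only one here beyond the scatter, while a 1.4-fold lower number from compound 2 to compound 3 (0.16 log units; within the scatter) stays within it. Exchanging the aryl group at this position has therefore produced at most a modest shift, and only in the direction of a higher number in this assay.

For compound 4 the expected step is a 1.2-fold higher number from compound 3 to compound 4 (0.08 log units; within the scatter), a change that may well remain inside the scatter. The estimated value for compound 4 is 36000 nM, with a likely range from 15000 nM to 85000 nM.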

Compound 4, concentration for total growth inhibition: 18200 nM
Compound 4: the middle estimate sits 2.0-fold (0.30 log units) above what was measured, within the range that was stated.
By their numbers in this assay, from the lowest: compounds 1, 4, 3 and 2 (each within the scatter of the next, the first and the last beyond it).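

In this assay, the exchange of 2-methoxyphenyl for 4-ethoxyphenyl on this saturated chain carbon gives a 1.7-fold lower number from compound 3 to compound 4 (0.22 log units; within the scatter) and so cannot be told apart from no change, even though the group's name and its place on the ring both differ. The new compound does sharpen the picture of compound 2, since a 2.4-fold lower number from compound 2 to compound 4 (0.38 log units; beyond the scatter) is a second step at this position beyond the scatter, and 4-nitrophenyl now stands apart from both 2-chlorophenyl and 4-ethoxyphenyl, though not from 2-methoxyphenyl in compound 3, which goes against any clean separation. The step of a 1.0-fold higher number from compound 1 to compound 4 (0.01 log units; within the scatter) also shows that 4-ethoxyphenyl and 2-chlorophenyl cannot be separated here, so quite different aryl groups can give matching numbers in this position.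

An aryl group carrying an amine or a carboxylic acid could show whether this position allows any larger shift than the modest ones seen so far. No supporting measurement is available to explain why these aryl groups give the numbers they do.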